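Switching the amide of compound 2 for a thioamide chain

A few compounds are considered here, and "the series" means these few. Any claim that something is new, unique, unknown or untested is made for them only; others in the source may bear on it.

Compound 1 `CNC(=O)C1=CC(C)(CF)Oc2ccc([N+](=O)[O-])cc21`: 66%
Compound 2 `CNC(=O)C1=CC(C)(C(F)(F)F)Oc2ccc([N+](=O)[O-])cc21`: 61.7%
Compound 3 `CNC(=O)C1=CC(C(F)(F)F)(C(F)(F)F)Oc2ccc([N+](=O)[O-])cc21`: 57.9%

In a functional assay on the whole organism (aorta) with Rattus norvegicus as the target (on this read-out lower numbers stand for smaller maximal responses and higher numbers for larger maximal responses), compound 2 sits among the other two: a number 4.3 percentage points lower from compound 1 to compound 2 (within the scatter) and a number 3.8 percentage points lower from compound 2 to compound 3 (within the scatter) both lie within the scatter, so the three compounds are indistinguishable on this read-out. Compound 4 `CC1(C(F)(F)F)C=C(/C(S)=N\CCC#N)c2cc([N+](=O)[O-])ccc2O1` differs from compound 2 in one place: a group of 7 heavy atoms (4 carbon, 2 nitrogen, 1 sulfur; no ring) in place of a group of 4 heavy atoms (2 carbon, 1 nitrogen, 1 oxygen; no ring), on a double-bonded ring carbon. Neither measured step touches this position; both concern the saturated ring carbon only, and neither was larger than the scatter, so the data give no guidance on the size or direction of this change. The step for this change is therefore only an estimate: it is expected to be a number 6.7 percentage points lower from compound 2 to compound 4 (within the scatter), and this expectation carries a wide band. Compound 4 is estimated at 55%, within 20% to 85%.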

Compound 4, intrinsic activity: the largest response reached, in percent of the reference agonist's: 69.7%
For compound 4 the middle estimate is 14.7 percentage points below the measured one; the range from low to high includes it.
By their numbers in this assay, from the lowest: compounds 3, 2, 1 and 4 (each within the scatter of the next, the first and the last beyond it).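

This is the first change shown at the double-bonded ring carbon. In this assay, replacing methylcarbamoyl with the larger chain ending in a nitrile gives a number 8 percentage points higher from compound 2 to compound 4 (within the scatter), so this position tolerates a quite different group with no difference that stands clear of the usual scatter. Nothing measured here bears on the reason for this result.

On these data alone, the sulfur and the longer chain enter together, so their separate contributions remain open. Also open, as far as these compounds go, is how an amine or a carboxylic acid on this carbon would behave.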